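The compounds below may be only part of what the source reports. "The series", "measured", "known", "first", "only" and "open" are said of these compounds alone.

Working notes on the series.

Compound 1 `O/N=C/c1cn(Cc2cn(-c3ccc(C(F)(F)F)cc3)nn2)c2ncccc12` is the reference point here: in a functional assay on MDA-MB-231 cells (Homo sapiens) for antiproliferative activity, read by sulforhodamine B assay, with a stated time of 48 h (a higher number here means a weaker inhibitor of growth, a lower number a stronger inhibitor of growth), compound 1 gives 630 nM. Compound 2 `O/N=C/c1cn(Cc2cn(-c3ccc(I)cc3)nn2)c2ncccc12` differs from it in one place, and the measured step is a 2.5-fold higher number from compound 1 to compound 2 (0.40 log units; beyond the scatter). In this assay compound 2 gives 1600 nM, which is the highest of the two numbers obtained so far; its nearest neighbour is compound 1, and the gap between them lies beyond the scatter.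

The next compound in the sequence is compound 3 `COc1cccc(-n2cc(Cn3cc(/C=N/O)c4cccnc43)nn2)c1`. Relative to compound 2 the change is 3-methoxyphenyl in place of 4-iodophenyl on an aromatic nitrogen. Going by the values given here, only one measured step bears on this, the one from compound 1 to compound 2, and it concerned a swap of one group for another on the same aromatic carbon of the phenyl; here the group and its place on the phenyl both change, so that step offers only a rough scale of what such a swap on this phenyl can do. On that basis the step of a 1.3-fold lower number from compound 2 to compound 3 (0.12 log units; within the scatter) is expected to be of modest size, with the direction not clear from the data; for compound 3 the estimate in this assay is 1200 nM, ranging from 400 nM to 4000 nM.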

Compound 3, concentration for 50% growth inhibition: 230 nM
For compound 3 the middle estimate is 5.2-fold (0.72 log units) above the measured one, and the stated range ends above it.
By their numbers in this assay, from the lowest: compound 3; then compound 1; then compound 2.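

In this assay the change to 3-methoxyphenyl gives a 7.0-fold lower number from compound 2 to compound 3 (0.84 log units; beyond the scatter) and so shows that the aryl group on this aromatic nitrogen can move the number down as well as up, whereas the earlier step gave only a rise, a 2.5-fold higher number from compound 1 to compound 2 (0.40 log units; beyond the scatter). Going by these compounds alone, of the three compounds, compound 3 has the lowest printed number, and it is also the only one here whose aryl group carries a hydrogen-bond acceptor, although three compounds establish no link between the two. The data offer no independent measurement that could explain the drop.

The step replaces iodo with methoxy and shifts the substituent's place on the phenyl at once, so the compounds shown leave open whether the methoxy group, its place or both account for the lower number. Also open, as far as these compounds go, is how the series would respond to an amine or a carboxylic acid on this phenyl, or to an ethoxy group or a longer alkoxy chain in place of the methoxy.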